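From 2-methoxyphenyl to 4-(trifluoromethyl)phenyl on the amide-type nitrogen

The source may report more compounds than this note shows. Statements on the series, on what has been measured and on what is new or still open speak of the compounds shown alone.

In an ADME assay on HUVEC cells (Homo sapiens) for cytotoxicity, read by MTT assay, with a stated time of 72 h (on this read-out lower numbers stand for stronger inhibition and higher numbers for weaker inhibition), compound 1 `O=C(O)CCC(=O)OCCCCCCSc1ccc([N+](=O)[O-])c2nonc12` gives 740 nM, compound 2 `O=C(CCC(=O)OCCCCCCSc1ccc([N+](=O)[O-])c2nonc12)Nc1ccccc1F` gives 840 nM and compound 3 `COc1ccccc1NC(=O)CCC(=O)OCCCCCCSc1ccc([N+](=O)[O-])c2nonc12` gives 1610 nM. Compound 3 stands at the upper end of these numbers. Against compound 1 the gap is beyond the scatter, with a 2.2-fold higher number from compound 1 to compound 3 (0.34 log units; beyond the scatter). Against compound 2 it is not, with a 1.9-fold higher number from compound 2 to compound 3 (0.28 log units; within the scatter).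

Compound 4 `O=C(CCC(=O)OCCCCCCSc1ccc([N+](=O)[O-])c2nonc12)Nc1ccc(C(F)(F)F)cc1` is the next to be read. It carries 4-(trifluoromethyl)phenyl in place of 2-methoxyphenyl on an amide-type nitrogen.

Among the compounds with values here, no measured compound carries trifluoromethyl, so no step speaks for this group directly. The nearest evidence is the change of aromatic group between compound 2 and compound 3, which stays within the scatter, at a 1.9-fold higher number from compound 2 to compound 3 (0.28 log units; within the scatter). Replacing hydroxy with an aromatic amino group has also moved the number little, with a 1.1-fold higher number from compound 1 to compound 2 (0.06 log units; within the scatter) for compound 2 and a modest shift for compound 3. No step beyond the scatter is therefore expected in this assay, with at most a slight lean towards the lower numbers of compound 1 and compound 2. The expected step is a 1.3-fold lower number from compound 3 to compound 4 (0.13 log units; within the scatter). For compound 4 the estimated value is 1200 nM, within an expected range of 550 nM to 2600 nM.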

Compound 4, half-maximal inhibitory concentration: 1390 nM
The estimate for compound 4 lay 1.2-fold (0.06 log units) below the measured number; measured number inside the range.
By their numbers in this assay, from the lowest: compounds 1, 2, 4 and 3 (each within the scatter of the next, the first and the last beyond it).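

In this assay, within the data shown here, 4-(trifluoromethyl)phenyl takes the place of 2-methoxyphenyl on the amide-type nitrogen with a 1.2-fold lower number from compound 3 to compound 4 (0.06 log units; within the scatter), so this position now carries a third aromatic group with no step that stands clear of the scatter. Among these compounds, the step from the 2-fluorophenyl group, a 1.7-fold higher number from compound 2 to compound 4 (0.22 log units; within the scatter), and the step from hydroxy on the carbonyl carbon, a 1.9-fold higher number from compound 1 to compound 4 (0.27 log units; within the scatter), also stay within the scatter, leaving a 2.2-fold higher number from compound 1 to compound 3 (0.34 log units; beyond the scatter) as the only step in the set beyond it, so an aromatic amino group in place of hydroxy does not always produce such a step. No measurement of any property of these groups bears on this result.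

Still open, on these data alone, is whether an alkylamine or a cyclic amine such as morpholine on the carbonyl carbon, in place of these aromatic amino groups, would give a step beyond the scatter. Also open is how the number responds to a longer chain in the linker, since all the compounds shown share the same chain and differ only on the carbonyl carbon.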